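The source may report more compounds than this note shows. Statements on the series, on what has been measured and on what is new or still open speak of the compounds shown alone.

Measured compounds:
Compound 1, `CCCOC(=O)Nc1ccc(S(=O)(=O)N2C[C@H](c3ccccc3)NC2=O)cc1CC`: 60 nM
Compound 2, `CCCCOC(=O)Nc1ccc(S(=O)(=O)N2C[C@H](c3ccccc3)NC2=O)cc1CC`: 200 nM
Compound 3, `CCOC(=O)Nc1ccc(S(=O)(=O)N2C[C@H](c3ccccc3)NC2=O)cc1F`: 5000 nM

In a functional assay on HCT-116 cells (Homo sapiens) for cytotoxicity, read by MTT assay (on this read-out lower numbers stand for stronger inhibition and higher numbers for weaker inhibition), compound 1 gives the lowest of the three numbers. Its nearest neighbour is compound 2, which shows a 3.3-fold higher number from compound 1 to compound 2 (0.52 log units; beyond the scatter); compound 3 lies far from both, and its number stands well above that of compound 1.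

Compound 4, `CCOC(=O)Nc1ccc(S(=O)(=O)N2C[C@H](c3ccccc3)NC2=O)cc1CC`, has not yet been measured in this assay. It differs from compound 1 as follows: hydrogen in place of methyl on a saturated chain carbon, two bonds along the chain from an oxygen next to a carbonyl group The same difference, cut one bond further out, reads propoxy to ethoxy. Within the data shown here, only one measured step bears on it: a 3.3-fold higher number from compound 1 to compound 2 (0.52 log units; beyond the scatter), which went the other way along the chain and lengthened it by a methyl. Among the measured compounds shown here, no step in the set shortens the chain on the shared core of compound 1. Compound 3 also carries the ethoxy group, but it differs from compound 4 in a second place as well, so its number cannot be taken as a direct guide.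

Given that lengthening the chain raised the number beyond the scatter, the expectation is that shortening it will not lower the number and may raise it somewhat, a step of a 2.0-fold higher number from compound 1 to compound 4 (0.30 log units; within the scatter). Compound 4 is therefore estimated at 120 nM, with a range from 35 nM to 450 nM.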

Compound 4, half-maximal inhibitory concentration: 70 nM
Estimate against measurement, compound 4: 1.7-fold (0.23 log units) above; low and high end bracket the measured number.
By their numbers in this assay, from the lowest: compounds 1 and 4 (each within the scatter of the next); then compound 2; then compound 3.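

In this assay, replacing propoxy with ethoxy on the shared core gives a step that stays within the scatter (a 1.2-fold higher number from compound 1 to compound 4 (0.07 log units; within the scatter)), whereas the longer chain of compound 2 stands apart from the ethoxy compound by a step beyond the scatter (a 2.9-fold lower number from compound 2 to compound 4 (0.46 log units; beyond the scatter)); among these three compounds, only the longest chain separates from the others. With ethoxy now held constant, the large gap of compound 3 can be read as a single change, ethyl in place of fluoro on an aromatic carbon (a 71-fold lower number from compound 3 to compound 4 (1.85 log units; beyond the scatter)). No measurement at hand accounts for either effect.

As far as these compounds go, it stays open how a methoxy group or a branched isopropoxy chain would read at this position. From the compounds shown here alone, it is equally open whether a chloro or methyl group on that aromatic carbon would behave like ethyl or like fluoro.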